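Anilino ring variation on the shared core: compound 4

The source may report more compounds than this note shows. Statements on the series, on what has been measured and on what is new or still open speak of the compounds shown alone.

Compound 1 `Fc1cccc(-c2nc(Nc3ccccc3)c3cc(F)ccc3n2)c1` gives 48300 nM in a functional assay on HL-60 cells (Homo sapiens) for cytotoxicity, read by MTT assay, with a stated time of 48 h; on this read-out lower numbers stand for stronger inhibition and higher numbers for weaker inhibition. Compound 3 `Fc1cccc(Nc2nc(-c3cccc(F)c3)nc3ccc(F)cc23)c1` gives 43100 nM in this assay. For compound 2 `COc1ccccc1Nc1nc(-c2cccc(F)c2)nc2ccc(F)cc12` the result in this assay is a limit of the assay, > 50000 nM. Among the numbers shown, compound 3 and compound 1 sit together, the step of a 1.1-fold lower number from compound 1 to compound 3 (0.05 log units; within the scatter) falling within the scatter; the third value shown is a limit (the limit of > 50000 nM in this assay, at which 1 of the 3 values shown sits). Compound 4 `Fc1cccc(-c2nc(Nc3ccc(Cl)cc3)c3cc(F)ccc3n2)c1` differs from compound 3 by 4-chlorophenyl in place of 3-fluorophenyl on a nitrogen on an aromatic ring. The measured step that bears on this most closely is the earlier swap on a nitrogen on an aromatic ring, an at least 1.1-fold lower number from compound 2 to compound 3 (0.06 log units; that floor lies within the scatter), read against a limit; the other two changes on the shared core, an at least 1.0-fold higher number from compound 1 to compound 2 (0.01 log units; that floor lies within the scatter) and a 1.1-fold lower number from compound 1 to compound 3 (0.05 log units; within the scatter), were also within the scatter. Every measured step in this assay has so far been flat, so no step beyond the scatter is expected for compound 4 in either direction, the expected step being a 1.0-fold lower number from compound 3 to compound 4 (0.00 log units; within the scatter). The estimate for compound 4 in this assay is 43000 nM, with a range from 20000 nM to 100000 nM.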

Compound 4, half-maximal inhibitory concentration: 45700 nM
Estimate against measurement, compound 4: 1.1-fold (0.03 log units) below; low and high end bracket the measured number.
By their numbers in this assay, from the lowest: compounds 3, 4 and 1 (each within the scatter of the next). At a limit, above all of these: compound 2.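

In this assay, the change on a nitrogen on an aromatic ring now includes a chlorine-bearing ring, and the swap of 3-fluorophenyl for 4-chlorophenyl stays flat, with a 1.1-fold higher number from compound 3 to compound 4 (0.03 log units; within the scatter). Chloro in place of hydrogen on the phenyl ring of compound 1 is just as flat, with a 1.1-fold lower number from compound 1 to compound 4 (0.02 log units; within the scatter), so chloro joins fluoro among the substituents here that give no step beyond the scatter. The step from the 2-methoxyphenyl of compound 2 yields only a floor, an at least 1.0-fold lower number from compound 2 to compound 4 (0.03 log units; that floor lies within the scatter), and it is read against a limit: the limit of > 50000 nM in this assay, at which 1 of the 4 values shown sits.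

No step shown lies beyond the scatter, so it remains open whether any group on this ring can shift the number. An amine or a carboxylic acid on the ring, or a longer chain in its place on the nitrogen, remains an open case.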